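A few compounds are considered here, and "the series" means these few. Any claim that something is new, unique, unknown or untested is made for them only; others in the source may bear on it.

Working notes on the series. In an assay on RBL-1 cells for inhibition of Polyunsaturated fatty acid 5-lipoxygenase (Rattus norvegicus) (on this read-out higher numbers stand for weaker inhibition and lower numbers for stronger inhibition), compound 1 `O=C(/C=C/c1ccc(O)c(O)c1)c1c(O)cc(O)cc1O` gives 140 nM, compound 2 `O=C(/C=C/c1ccc(O)c(O)c1)c1ccccc1-c1cccnc1` gives 210 nM, and compound 3 `Cc1cccc(C(=O)/C=C/c2ccc(O)c(O)c2)c1` gives 27 nM. Compound 2 carries the highest number of the three; its gap to compound 1 lies within the scatter, while compound 3 sits beyond the scatter at a clearly lower number. Compound 4 `COc1ccccc1C(=O)/C=C/c1ccc(O)c(O)c1` has not yet been measured in this assay. It differs from compound 2 by methoxy in place of pyridin-3-yl on an aromatic carbon. For the measured compounds named here, no measured pair isolates this change. Compound 3, which also carries a small group on its six-membered aromatic ring of carbon only, gives 27 nM, so a moderate move toward lower numbers is expected. The expected step is a 2.6-fold lower number from compound 2 to compound 4 (0.42 log units; beyond the scatter). Compound 4 is estimated at 80 nM, within a range of 25 nM to 250 nM.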

Compound 4, half-maximal inhibitory concentration: 27 nM
Beside the measured number, compound 4's estimate is 3.0-fold (0.47 log units) above it; low and high end bracket the measured number.
By their numbers in this assay, from the lowest: compounds 3 and 4 (each within the scatter of the next); then compounds 1 and 2 (each within the scatter of the next).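

At this aromatic carbon, ortho to a large group, methoxy in place of pyridin-3-yl gives a 7.8-fold lower number from compound 2 to compound 4 (0.89 log units; beyond the scatter) in this assay. For the compounds shown here, this is the first pair that differs in one place, and it shows that the number at this position depends on the group carried there, even though both groups count the same hydrogen-bond acceptors. Nothing at hand explains the step.

As far as these compounds go, whether the lower number goes with fewer heavy atoms or with the loss of the ring stays open. A phenyl, an ethoxy or a hydroxy group on this carbon would separate the two.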